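The compounds below may be only part of what the source reports. "The series", "measured", "known", "first", "only" and "open" are said of these compounds alone.

Measured in an in vivo ADME assay on the whole organism (strain Han Wistar) for metabolic stability, with Rattus norvegicus as the target; on this read-out lower numbers stand for a shorter-lived compound and higher numbers for a longer-lived compound:
- compound 1 `CCCC[C@H](NC(=O)O[C@@H]1C(=O)N(C(=O)c2nc3ccccc3s2)CC1(C)C)C(=O)C(=O)Nc1cc[nH]n1`: 3 h
- compound 2 `CCCC[C@H](NC(=O)O[C@@H]1C(=O)N(C(=O)c2ccno2)CC1(C)C)C(=O)C(=O)N[C@H](C)c1ccccc1`: 0.6 h

For the measured compounds named here, of the two numbers in this assay, compound 1 stands highest; compound 2 lies lower by a margin beyond the scatter, but the two differ at several places, so no single-site step is available. Compound 3 `CCCC[C@H](NC(=O)O[C@@H]1C(=O)N(C(=O)c2nnc(C(F)(F)F)s2)CC1(C)C)C(=O)C(=O)Nc1cc[nH]n1` differs from compound 1 only by 5-(trifluoromethyl)-1,3,4-thiadiazol-2-yl in place of 1,3-benzothiazol-2-yl on a carbonyl carbon. Going by the values given here, with no measured step for such a change, the step from compound 1 to compound 3 is expected to be small, a 1.2-fold lower number from compound 1 to compound 3 (0.08 log units; within the scatter), not clearly beyond the scatter in either direction. Compound 3 is therefore estimated at 2.5 h in this assay, within a range of 1 h to 6 h.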

Compound 3, half-life: 1.35 h
Estimate against measurement, compound 3: 1.9-fold (0.27 log units) above; measured number inside the range.
By their numbers in this assay, from the lowest: compound 2; then compound 3; then compound 1.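

In this assay, for the compounds shown here, the group on this carbonyl carbon can be read on its own for the first time: 5-(trifluoromethyl)-1,3,4-thiadiazol-2-yl in place of 1,3-benzothiazol-2-yl gives a 2.2-fold lower number from compound 1 to compound 3 (0.35 log units; beyond the scatter) and so shifts the half-life modestly, beyond the scatter. This is a single pair, so it sets no trend for the position. Nothing available accounts for the step.

The change removes the six-membered aromatic ring and adds the trifluoromethyl together, leaving their separate shares open. A 1,3,4-thiadiazol-2-yl carrying a methyl group instead of trifluoromethyl would separate them.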